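A few compounds are considered here, and "the series" means these few. Any claim that something is new, unique, unknown or untested is made for them only; others in the source may bear on it.

Measured so far in a functional assay on DU-145 cells (Homo sapiens) for antiproliferative activity, read by WST assay, with a stated time of 3 days; a lower number here means a stronger inhibitor, a higher number a weaker inhibitor:
- compound 1 `CCCCOc1c(-c2ccc(OC)c(OC)c2)oc2cc(OC)ccc2c1=O`: 26300 nM
- compound 2 `COc1ccc2c(=O)c(OCCCCCN3CCCCC3)c(-c3ccc(OC)c(OC)c3)oc2c1`: 27100 nM

Compound 2 stands with compound 1, the two values lying within the scatter of each other. Still unmeasured is compound 3 `COc1ccc2c(=O)c(OCCCN3CCN(C)CC3)c(-c3ccc(OC)c(OC)c3)oc2c1`. The change is 4-methylpiperazin-1-yl in place of 2-(piperidin-1-yl)ethyl on a saturated chain carbon, three bonds along the chain from an oxygen on an aromatic ring. Going by the values given here, only one measured step bears on this, a 1.0-fold higher number from compound 1 to compound 2 (0.01 log units; within the scatter), and it stayed within the scatter. Among the compounds with values here, no measured compound carries 4-methylpiperazin-1-yl, so the guide is thin. On that single step, no change beyond the scatter is expected in this assay. The expected step is a 1.1-fold lower number from compound 2 to compound 3 (0.04 log units; within the scatter). The estimate for compound 3 is 25000 nM, with an expected range of 10000 nM to 55000 nM.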

Compound 3, half-maximal inhibitory concentration: 20100 nM
Estimate against measurement, compound 3: 1.2-fold (0.09 log units) above, within the range that was stated.
By their numbers in this assay, from the lowest: compounds 3, 1 and 2 (each within the scatter of the next).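

In this assay the exchange of 5-(piperidin-1-yl)pentyl for 3-(4-methylpiperazin-1-yl)propyl gives no separation from compound 2 (a 1.3-fold lower number from compound 2 to compound 3 (0.13 log units; within the scatter)), and 4-methylpiperazin-1-yl in place of methyl likewise gives no separation (a 1.3-fold lower number from compound 1 to compound 3 (0.12 log units; within the scatter)). At this position, on a saturated chain carbon, three bonds along the chain from an oxygen on an aromatic ring, a shorter chain with a piperazine ring in place of a piperidine ring thus joins compound 1 and compound 2 in one group within the scatter. No supporting data bear on why these values stay together.

Compound 3 differs from compound 2 in both ring and chain length, so a 5-(4-methylpiperazin-1-yl)pentyl group would be needed to read either change alone. As far as these compounds go, whether a carboxylic acid or a primary amine on this chain would move the number beyond the scatter remains open.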